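A few compounds are considered here, and "the series" means these few. Any claim that something is new, unique, unknown or untested is made for them only; others in the source may bear on it.

Measured so far in a functional assay on Hep 3B2 cells (Homo sapiens) for antiproliferative activity, read by MTT assay, with a stated time of 24 h, tested at 11.11 ug/mL; on this read-out higher numbers stand for a stronger effect at the one concentration tested and lower numbers for a weaker effect:
- compound 1 `CCc1ccc2nc(C(=O)Nc3c(F)cc(-c4cccc(F)c4)cc3F)c(C)c(C(=O)O)c2c1`: 27.2%
- compound 2 `CCOc1ccc2nc(C(=O)Nc3c(F)cc(-c4cccc(F)c4)cc3F)c(C)c(C(=O)O)c2c1`: 33.2%

Compound 2 stands highest of the two numbers in this assay, but its nearest neighbour, compound 1, sits at a step that is within the scatter, so the two values cannot be ordered. Going by the values given here, the one measured step, a number 6 percentage points higher from compound 1 to compound 2 (within the scatter), swaps ethyl for ethoxy on an aromatic carbon and shows no effect beyond the scatter.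

Compound 3 `COc1ccc2nc(C(=O)Nc3c(F)cc(-c4cccc(F)c4)cc3F)c(C)c(C(=O)O)c2c1` is the next member. Against compound 2 the change is hydrogen in place of methyl on a saturated chain carbon bound to an oxygen on an aromatic ring, so the ethoxy of compound 2 becomes a methoxy. Among the compounds with values here, no measured step shortens an alkyl chain, so the only bearing step is a number 6 percentage points higher from compound 1 to compound 2 (within the scatter), which touches the same aromatic carbon and was within the scatter. On that basis the step in this assay is expected to be small or absent, in either direction.

For compound 3 the expected read-out in this assay is 30%, with a range from 18% to 42%; the expected step is a number 3.2 percentage points lower from compound 2 to compound 3 (within the scatter).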

Compound 3, a percentage reported as inhibition, at one concentration (the size of the read-out at that concentration, not a potency): 2.34%
Beside the measured number, compound 3's estimate is 27.7 percentage points above it; the whole stated range lies above it.
By their numbers in this assay, from the lowest: compound 3; then compounds 1 and 2 (each within the scatter of the next).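

In this assay the change from ethoxy to methoxy on this aromatic carbon gives a number 30.9 percentage points lower from compound 2 to compound 3 (beyond the scatter) and so shows that a single carbon in the chain on this oxygen can separate a clear reading from a much lower one, which the earlier pair could not show. The same low level appears against the ethyl compound, with a number 24.9 percentage points lower from compound 1 to compound 3 (beyond the scatter) in the same read-out, whereas a number 6 percentage points higher from compound 1 to compound 2 (within the scatter) leaves ethyl and ethoxy unresolved; the oxygen alone therefore does not set the level, as ethoxy and methoxy both carry it, and within these three compounds only methoxy stands apart. No evidence on hand accounts for the drop.

The compounds shown leave open whether a longer chain such as propoxy or butoxy stays at the level of ethoxy, and whether a hydroxyl group or a bare hydrogen on this aromatic carbon falls with methoxy or with ethyl and ethoxy. Each reading also comes from one concentration, so the numbers tell only how strong or weak the effect of the three compounds is at that concentration and nothing about other concentrations.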